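A few compounds are considered here, and "the series" means these few. Any claim that something is new, unique, unknown or untested is made for them only; others in the source may bear on it.

Of the compounds shown here, three built on one shared core have been measured in a functional assay on BGC-823 cells (Homo sapiens) for inhibition, read by MTT assay, with a stated time of 72 h; on this read-out lower numbers stand for stronger inhibition and higher numbers for weaker inhibition. Compound 1 `COc1cc2c(Nc3ccc(F)cc3)ncnc2c(OC)c1OC` gives 39600 nM, compound 2 `COc1cc2c(Nc3ccc(Br)cc3Cl)ncnc2c(OC)c1OC` gives 31000 nM, and compound 3 `COc1cc2c(Nc3cccc(Cl)c3)ncnc2c(OC)c1OC` gives 19000 nM. Among the measured compounds shown here, only one of the three steps among them goes beyond the scatter, a 2.1-fold lower number from compound 1 to compound 3 (0.32 log units; beyond the scatter). The other two, a 1.3-fold lower number from compound 1 to compound 2 (0.11 log units; within the scatter) and a 1.6-fold lower number from compound 2 to compound 3 (0.21 log units; within the scatter), do not, so compound 3 cannot be separated from compound 2.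

The unmeasured compound 4 `COc1cc2c(Nc3ccc(Cl)cc3)ncnc2c(OC)c1OC` has the same atoms as compound 3, joined differently: 4-chlorophenyl in place of 3-chlorophenyl on a nitrogen on an aromatic ring. For the measured compounds named here, no measured step makes exactly this change. The nearest guides are compound 1, with 4-fluorophenyl, and compound 2, with 4-bromo-2-chlorophenyl, since both groups resemble 4-chlorophenyl more closely than 3-chlorophenyl does. The step that bears most directly is a 2.1-fold lower number from compound 1 to compound 3 (0.32 log units; beyond the scatter), and compound 4 would run roughly back along it, although that step also exchanges one halogen for another. A rise in this assay of similar or smaller size is therefore expected, and it may stay within the scatter. The estimated change is a 1.5-fold higher number from compound 3 to compound 4 (0.18 log units; within the scatter). The expected value for compound 4 is 29000 nM, with an estimated range from 14000 nM to 58000 nM.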

Compound 4, half-maximal inhibitory concentration: 34400 nM
For compound 4 the middle estimate is 1.2-fold (0.07 log units) below the measured one, within the range that was stated.
By their numbers in this assay, from the lowest: compounds 3, 2, 4 and 1 (each within the scatter of the next, the first and the last beyond it).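

Exchanging 3-chlorophenyl for 4-chlorophenyl on a nitrogen on an aromatic ring keeps the halogen the same and changes only where it sits, and in this assay this gives (a 1.8-fold higher number from compound 3 to compound 4 (0.26 log units; within the scatter)), so these two isomers cannot be told apart. The other two new comparisons do not separate compound 4 from its neighbours either: chloro in place of fluoro on an aromatic carbon gives (a 1.2-fold lower number from compound 1 to compound 4 (0.06 log units; within the scatter)), and 4-chlorophenyl in place of 4-bromo-2-chlorophenyl gives (a 1.1-fold higher number from compound 2 to compound 4 (0.05 log units; within the scatter)). Among the compounds shown here, compound 4 therefore lies within the scatter of both compound 1 and compound 3, the one pair that stands beyond it, so that gap cannot be assigned to the identity of the halogen or to its place alone.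

Nothing available here explains why any of these numbers fall where they do. Still open, from the compounds shown here alone, is whether a group other than a halogen on the phenyl ring, such as a nitrile or an amine, or a longer chain in place of a methoxy group on the shared core, would give a step clearly beyond the scatter.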